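The source may report more compounds than this note shows. Statements on the series, on what has been measured and on what is new or still open speak of the compounds shown alone.

Measured so far in an ADME assay on cells (Macrophage, Homo sapiens) for cytotoxicity, read by MTT assay, with a stated time of 24 h; a lower number here means that less compound is tolerated, a higher number that more compound is tolerated:
compound 1 `CC(O)Cn1c([N+](=O)[O-])cnc1/C=C/c1ccc(Cl)cc1`: 980 nM
compound 2 `CC(O)Cn1c([N+](=O)[O-])cnc1/C=C/c1cccc(Cl)c1`: 520 nM
compound 3 `CC(O)Cn1c([N+](=O)[O-])cnc1/C=C/c1ccccc1Cl`: 480 nM

Compound 1 has the highest of the three numbers, but the margin is slim: a 1.9-fold lower number from compound 1 to compound 2 (0.28 log units; within the scatter) and a 2.0-fold lower number from compound 1 to compound 3 (0.31 log units; beyond the scatter), the latter modest. Compound 2 and compound 3 sit within the scatter of each other, a 1.1-fold lower number from compound 2 to compound 3 (0.03 log units; within the scatter). All three measured steps move the chloro around the phenyl ring and leave its identity untouched.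

Compound 4 `CC(O)Cn1c([N+](=O)[O-])cnc1/C=C/c1ccc(N(C)C)cc1` goes a different way: dimethylamino in place of chloro on an aromatic carbon. Within the data shown here, no measured step swaps the group itself, so none of the three steps bears directly on this change; the only guide is that moving the chloro shifted this assay by at most a modest amount across the series. The step from compound 1 to compound 4 in this assay is therefore expected to be small, in either direction, most likely not beyond the scatter, with wide uncertainty because the change is of a new kind. The expected step is a 1.0-fold higher number from compound 1 to compound 4 (0.01 log units; within the scatter). For compound 4 the estimate is 1000 nM, with a range from 400 nM to 2500 nM.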

Compound 4, half-maximal cytotoxic concentration: 680 nM
For compound 4 the middle estimate is 1.5-fold (0.17 log units) above the measured one; the range from low to high includes it.
By their numbers in this assay, from the lowest: compounds 3, 2, 4 and 1 (each within the scatter of the next, the first and the last beyond it).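

In this assay, among these compounds, the step for dimethylamino in place of chloro on an aromatic carbon, para to a large group, is a 1.4-fold lower number from compound 1 to compound 4 (0.16 log units; within the scatter) and concerns the group itself, whereas the earlier steps only moved the chloro around the ring. At this place, one chlorine can thus give way to dimethylamino, with more heavy atoms and a hydrogen-bond acceptor, without the step leaving the scatter. No measured evidence explains this small step.

The compounds shown leave open whether the same holds for other groups at this place, such as a carboxylic acid, a methoxy group or a longer chain on the amine. They also leave open whether dimethylamino would match the chloro series at the other ring places.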